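Removing the chloro group from compound 2

A few compounds are considered here, and "the series" means these few. Any claim that something is new, unique, unknown or untested is made for them only; others in the source may bear on it.

Compound 1 (`COc1ccc(-c2nc3sc(-c4ccccc4)cn3n2)cc1`) gives 45% growth inhibition
Compound 2 (`Clc1ccc(-c2cn3nc(-c4ccccc4)nc3s2)cc1`) gives 19% growth inhibition

In a functional assay on LOX IMVI cells (Homo sapiens) for inhibition, read by sulforhodamine B assay, with a stated time of 48 h, tested at 10 uM (a higher number here means more inhibition of growth at the concentration tested, a lower number less inhibition of growth), compound 2 gives 19% and stands lowest of the two, with compound 1 higher by a gap beyond the usual scatter. Compound 3 (`c1ccc(-c2nc3sc(-c4ccccc4)cn3n2)cc1`) arises from compound 2 through one change (hydrogen in place of chloro on an aromatic carbon), hydrogen in place of chloro on an aromatic carbon. Going by the values given here, no measured pair shows this change alone. A small rise, not beyond the usual scatter, is expected in this assay here. The expected move is a number 7 percentage points higher from compound 2 to compound 3 (within the scatter) in size. Compound 3 is estimated at 26% (expected range 8% to 45%).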

Compound 3, percent growth inhibition at one concentration: 16%
Estimate against measurement, compound 3: 10 percentage points above; the measured number falls inside the stated range.
By their numbers in this assay, from the lowest: compounds 3 and 2 (each within the scatter of the next); then compound 1.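

In this assay, the 4-chlorophenyl to phenyl change leaves compound 2 and compound 3 within the usual scatter of each other (a number 3 percentage points lower from compound 2 to compound 3 (within the scatter)), so the chloro group shows no measurable effect at this position. The methoxy group does register: hydrogen in its place gives a modest step beyond the scatter (a number 29 percentage points lower from compound 1 to compound 3 (beyond the scatter)). Compound 1 and compound 2 carry their groups in different places, so these steps do not compare the two groups at one position, and nothing available explains either result. Going by these compounds, whether an amine or a methoxy group on the carbon that held chloro would move the number stays open.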